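Adding a chloro group to a simple aryl keto acid

A few compounds are considered here, and "the series" means these few. Any claim that something is new, unique, unknown or untested is made for them only; others in the source may bear on it.

Measured so far:
compound 1, `O=C(O)/C=C/C(=O)c1ccccc1`, 30200 nM
compound 2, `CC(C)c1ccc(C(C)C)c(C(=O)/C=C/C(=O)O)c1`, 3280 nM
compound 3, `CC(C)c1cc(C(C)C)c(C(=O)/C=C/C(=O)O)c(C(C)C)c1`, 4670 nM

In a functional assay on K562 cells (Homo sapiens) for inhibition, read by MTT assay, with a stated time of 72 h (a higher number here means a weaker inhibitor, a lower number a stronger inhibitor), compound 1 gives 30200 nM, the highest number of the three. Compound 2, with two isopropyl groups on the ring, gives 3280 nM in this assay, and compound 3, with three, gives 4670 nM; both stand well below compound 1, beyond the usual scatter, while the two of them lie within scatter of each other.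

Compound 4, `O=C(O)/C=C/C(=O)c1ccc(Cl)cc1`, has not yet been measured. Compared with compound 1 it carries chloro in place of hydrogen on an aromatic carbon, a small change on the shared core of compound 1 at a place not tried among the measured compounds. Within the data shown here, since no measured pair shows this exact exchange, the expectation rests only on the observation that both ring-substituted compounds give lower numbers than compound 1. A modest step toward a lower number is expected, a 2.0-fold lower number from compound 1 to compound 4 (0.30 log units; within the scatter), smaller than the gap between compound 1 and compound 2 because compound 2 gives 3280 nM with two isopropyl groups, a much larger change than a single chloro. Compound 4 is therefore estimated at about 15000 nM, with a range from 5000 nM to 45000 nM.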

Compound 4, half-maximal inhibitory concentration: 21700 nM
The estimate for compound 4 lay 1.4-fold (0.16 log units) below the measured number, and the stated range covers the measured number.
By their numbers in this assay, from the lowest: compounds 2 and 3 (each within the scatter of the next); then compounds 4 and 1 (each within the scatter of the next).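

In this assay, chloro in place of hydrogen on an aromatic carbon, para to a group of 7 heavy atoms, gives a 1.4-fold lower number from compound 1 to compound 4 (0.14 log units; within the scatter). This is the first exchange among these compounds that changes only one place, so it gives a direct reading for this position: here, chloro and hydrogen cannot be told apart from the ordinary spread of repeated measurements. Nothing available explains this outcome or shows how the exchange acts in the cells.

From the compounds shown here alone, it remains open whether a different group at this same position, such as an amine, a methoxy group or a longer chain, would move the number beyond the scatter. Going by these compounds, it is also open whether chloro at another place on the ring would behave as it does here.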